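Pyrimidine for Pyridine on Two Vinyl Sulfone Cores

The source may hold more compounds than are shown below. What is called first, only, known or untested is meant among the compounds shown, and "the series" means these compounds.

Compound 1 `COc1ccccc1S(=O)(=O)/C=C/c1ccncc1` and compound 2 `COc1ccc(S(=O)(=O)/C=C/c2ccncc2)cc1` share the same atoms joined differently; the difference between the two cores is not broken down here. In an assay on U2OS cells for activation of nuclear factor erythroid 2-related factor 2 (Homo sapiens), read by chemiluminescence, with a stated time of 6 h (a lower number here means that less compound is needed, a higher number that more compound is needed for the effect), compound 1 gives 1520 nM. In this assay compound 2 gives 1200 nM, within the scatter of compound 1. Compound 3 `COc1ccccc1S(=O)(=O)/C=C/c1cncnc1` reaches only a limit of the assay, giving > 10000 nM. The change pyrimidin-5-yl in place of pyridin-4-yl on a double-bonded chain carbon bound to a double-bonded chain carbon thus produced an at least 6.5-fold higher number from compound 1 to compound 3 (0.81 log units; beyond the scatter), with the limit of > 10000 nM in this assay, at which 1 of the 3 values shown sits, marking the floor of that reading. Compound 4 `COc1ccc(S(=O)(=O)/C=C/c2cncnc2)cc1` carries the same change, (pyrimidin-5-yl in place of pyridin-4-yl on a double-bonded chain carbon bound to a double-bonded chain carbon), on the core of compound 2. The expected step for compound 4 is a 10-fold higher number from compound 2 to compound 4 (1.00 log units; beyond the scatter), resting on compound 1 and its measured step of an at least 6.5-fold higher number from compound 1 to compound 3 (0.81 log units; beyond the scatter). Compound 4 is therefore estimated at 12000 nM, most likely between 5000 nM and 40000 nM.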

Compound 4, half-maximal effective concentration: > 10000 nM
Compound 4: no number, only a limit (the forecaster's own chance of this, stated with the estimate: 65%); the middle value is on the limit's open side.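

On the core of compound 2, pyrimidin-5-yl in place of pyridin-4-yl gives an at least 8.3-fold higher number from compound 2 to compound 4 (0.92 log units; beyond the scatter), so the change moves the number the same way on both cores. In this assay compound 4 gives > 10000 nM, which is a limit and not a number. The result shows that the loss of effect carries over from one core to the other, but it does not show whether the size of the step is the same on both: the same change on two cores in this assay, an at least 6.5-fold higher number (0.81 log units; beyond the scatter) from compound 1 to compound 3 and an at least 8.3-fold higher number (0.92 log units; beyond the scatter) from compound 2 to compound 4; the limit leaves it open whether they differ

On these data alone, how far compound 3 and compound 4 actually lie past this limit remains open. Also open, as far as these compounds go, is how a different group in the same place, such as an amine or a carboxylic acid, would read on either core.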